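This account rests on a few compounds, and the source may have more. Where it says the series, first, only, none or still open, it means among the compounds named here.

Measured compounds:
- compound 1 `C[C@H](NC(=O)c1nnn(Cc2ccc(C(F)(F)F)cc2)c1C(F)(F)F)c1ccc(C(=O)O)cc1` gives > 10000 nM
- compound 2 `CCc1nnn(Cc2ccc(C(F)(F)F)cc2)c1C(=O)N[C@@H](C)c1ccc(C(=O)O)cc1` gives > 10000 nM
- compound 3 `C[C@H](NC(=O)c1c(-c2ccccc2)nnn1Cc1ccc(F)cc1)c1ccc(C(=O)O)cc1` gives 330 nM

In a functional assay on CHO cells for antagonist activity at prostaglandin E2 receptor EP4 subtype (Homo sapiens), read by calcium flux, with a stated time of 15 min (on this read-out higher numbers stand for weaker inhibition and lower numbers for stronger inhibition), compound 2 gives > 10000 nM, and this is a limit of the assay rather than a number. The same holds for compound 1, whose > 10000 nM is also a limit. For the measured compounds named here, compound 3 is the only member of the set with a measured number, 330 nM, so it is the only point against which any real inhibition can be judged. Compound 2 thus stands at the weak end of the measured range, with no number of its own; the limit of > 10000 nM in this assay, at which 2 of the 3 values shown sit, marks where two of the three results sit.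

The next compound, compound 4 `C=CCc1nnn(Cc2ccc(C(F)(F)F)cc2)c1C(=O)N[C@@H](C)c1ccc(C(=O)O)cc1`, differs from compound 2 by vinyl in place of methyl on a saturated chain carbon bound to an aromatic carbon. Going by the values given here, no step between two measured compounds bears on such a change, so there is no measured guide to its size. A small addition of this kind at a chain carbon is not expected to move the result beyond the scatter of the assay, and the step from a number no higher from compound 2 to compound 4 (the limit leaves the size open) is estimated to be none in practice, because compound 2 itself sits at the limit > 10000 nM. Compound 4 is therefore expected to give about 10000 nM, within 3000 nM to 30000 nM, most likely again reported only as a limit.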

Compound 4, half-maximal inhibitory concentration: > 1000 nM
Compound 4: a limit, no number; the forecaster's own chance of this, stated with the estimate: 70%; the middle value does not contradict the limit.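

Compound 2 at > 10000 nM is a limit, not a number. Compound 4 at > 1000 nM is likewise a limit, so no step can be read between compound 2 and compound 4. The compounds shown leave open whether vinyl in place of methyl on a saturated chain carbon bound to an aromatic carbon changes inhibition at all.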